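From compound 3 to compound 4: one added methoxy

The source may hold more compounds than are shown below. What is called first, only, known or untested is meant among the compounds shown, and "the series" means these compounds.

Compound 1 `CC(=O)c1ccc2[nH]c(-c3ccc(Cl)cc3)nc2c1` gives > 100000 nM (a limit)
Compound 2 `COc1ccc(-c2nc3cc(C(C)=O)ccc3[nH]2)c(OC)c1` gives > 100000 nM (a limit)
Compound 3 `COc1ccc(-c2nc3cc(C(C)O)ccc3[nH]2)cc1` gives > 100000 nM (a limit)

In an ADME assay on Vero cells (Chlorocebus sabaeus) for cytotoxicity, read by MTT assay, with a stated time of 96 h (a higher number here means that more compound is tolerated, a lower number that less compound is tolerated), compound 3 gives > 100000 nM, which is a limit and not a number. Within the data shown here, the whole set so far looks the same, with the limit of > 100000 nM in this assay, at which 3 of the 3 values shown sit, as the only evidence. Compound 4 `COc1ccc(-c2nc3cc(C(C)O)ccc3[nH]2)c(OC)c1` differs from compound 3 by methoxy in place of hydrogen on an aromatic carbon. Compound 2 shares these methoxy groups and gives > 100000 nM, again a limit. Among the measured compounds shown here, no measured step shows the size of this change, so no step beyond the scatter is expected in this assay. The estimated move is a number no higher from compound 3 to compound 4 (the limit leaves the size open), and it is expected to be small. For compound 4 the estimated value is 100000 nM, within an expected range of 50000 nM to 200000 nM, and another limit is likely.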

Compound 4, half-maximal cytotoxic concentration: > 100000 nM
Compound 4 was reported as a limit; the forecaster's own chance of this, stated with the estimate: 85%; the middle value lies on the limit itself.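

Compound 4 also gives only a limit, so its steps from compound 3 and from compound 2 cannot be read. What stays open in this assay is the concentration at which any of these compounds harms the cells: the limit of > 100000 nM in this assay, at which 4 of the 4 values shown sit.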